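A Hydroxy Swap on a Compound Resting at the Limit

The source may hold more compounds than are shown below. What is called first, only, known or untested is meant among the compounds shown, and "the series" means these compounds.

In a functional assay on HCT-116 cells (Homo sapiens) for inhibition, read by CCK-8 assay, with a stated time of 48 h (a higher number here means a weaker inhibitor, a lower number a stronger inhibitor), compound 1 `COc1cc(N(Cc2ccc(Br)cc2)C(=O)CSC(=S)N2CCN(C(=O)OC(C)(C)C)CC2)cc(OC)c1OC` gives 11400 nM. Compound 2 `COc1ccc(CN(C(=O)CSC(=S)N2CCN(C(=O)OC(C)(C)C)CC2)c2cc(OC)c(OC)c(OC)c2)cc1OC` gives > 20000 nM, which is a limit of the assay and not a number. Compound 3 `COc1ccc(CN(C(=O)CSC(=S)N2CCN(C(=O)OC(C)(C)C)CC2)c2cc(OC)c(OC)c(OC)c2)cc1C` gives > 20000 nM, which is also only a limit. Compound 3 therefore has no exact place on the scale of this assay, and this is the starting point for the next change.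

Compound 4 `COc1ccc(CN(C(=O)CSC(=S)N2CCN(C(=O)OC(C)(C)C)CC2)c2cc(OC)c(OC)c(OC)c2)cc1O` carries hydroxy in place of methyl on an aromatic carbon, ortho to a methoxy group: hydroxy in place of methyl on an aromatic carbon. The same difference reads 4-methoxy-3-methylphenyl to 3-hydroxy-4-methoxyphenyl.

Among the measured compounds shown here, three measured steps bear on this change. Two concern the group that replaces 4-bromophenyl: an at least 1.7-fold higher number from compound 1 to compound 2 (0.24 log units; that floor lies within the scatter) and an at least 1.7-fold higher number from compound 1 to compound 3 (0.24 log units; that floor lies within the scatter). The nearest swap, methyl in place of methoxy on an aromatic carbon, gives a step that the two limits leave unreadable from compound 2 to compound 3. For the measured compounds named here, no measured compound carries this hydroxy, so none of these steps sets a size or direction for the change, and the expectation rests on (the limit of > 20000 nM in this assay, at which 2 of the 3 values shown sit). No step beyond the scatter is expected. The expected change is an at least 1.1-fold lower number from compound 3 to compound 4 (0.04 log units; that floor lies within the scatter). Compound 4 is estimated at 18000 nM, with an expected range from 7000 nM to 40000 nM.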

Compound 4, half-maximal inhibitory concentration: 128 nM
Estimate against measurement, compound 4: 140-fold (2.15 log units) above; measured number outside the range, below it.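

Among the compounds shown here, at this aromatic carbon, ortho to a methoxy group, the choice of group matters far more than the earlier compounds could show. In this assay, hydroxy in place of methyl gives an at least 150-fold lower number from compound 3 to compound 4 (2.19 log units; beyond the scatter), and hydrogen in place of methyl on the oxygen gives an at least 150-fold lower number from compound 2 to compound 4 (2.19 log units; beyond the scatter), so removing only that methyl from the methoxy group is enough to produce a large step. Compared with the 4-bromophenyl group, the only one here with a readable starting value, the 3-hydroxy-4-methoxyphenyl group gives an 89-fold lower number from compound 1 to compound 4 (1.95 log units; beyond the scatter), which shows that the gain is measurable against an exact number and does not depend on a limit alone.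

The full size of the first two steps stays open, because each starts from a compound that rests at a limit and so gives only a floor: the limit of > 20000 nM in this assay, at which 2 of the 4 values shown sit. Also open is whether hydroxy is the only group that works here, since the compounds shown do not reveal how an amine or a carboxylic acid on this same aromatic carbon would behave.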